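Trading Trimethoxy for Hydroxy-Methoxy on the Enone Aryl

The source may hold more compounds than are shown below. What is called first, only, known or untested is meant among the compounds shown, and "the series" means these compounds.

Three compounds share one chalcone-like core and were tested in a functional assay on MCF7 cells (Homo sapiens) for inhibition; a lower number here means a stronger inhibitor of growth, a higher number a weaker inhibitor of growth. Compound 1 `COc1cc(/C=C/C(=O)c2cccc(-n3cc(-c4ccc(Cl)cc4)[nH]c3=O)c2)ccc1O` gives 2300 nM. For the measured compounds named here, compound 2 `COc1cc(/C=C/C(=O)c2cccc(-n3cc(-c4ccccc4)[nH]c3=O)c2)ccc1O` gives 1550 nM; the one measured step, a 1.5-fold lower number from compound 1 to compound 2 (0.17 log units; within the scatter), is small. Compound 3 `COc1ccc(-c2cn(-c3cccc(C(=O)/C=C/c4cc(OC)c(OC)c(OC)c4)c3)c(=O)[nH]2)cc1` gives 440 nM, the lowest number of the three, and its gap to compound 2 and to compound 1 lies beyond the scatter in each case.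

Compound 4 `COc1ccc(-c2cn(-c3cccc(C(=O)/C=C/c4ccc(O)c(OC)c4)c3)c(=O)[nH]2)cc1` is the next compound; it differs from compound 3 by 4-hydroxy-3-methoxyphenyl in place of 3,4,5-trimethoxyphenyl on a double-bonded chain carbon bound to a double-bonded chain carbon. Going by the values given here, no measured pair isolates this change: compounds 1 and 2 carry the same 4-hydroxy-3-methoxyphenyl as compound 4, but they also differ from compound 3 in the group on the shared core, so their higher numbers cannot be assigned to the enone aryl alone. The step from compound 1 to compound 2 touches a different position and is within the scatter, so it says nothing about this replacement.

The only hint is that the two compounds bearing 4-hydroxy-3-methoxyphenyl sit well above compound 3. Compound 4 is therefore expected to move toward them, with a step of a 2.7-fold higher number from compound 3 to compound 4 (0.44 log units; beyond the scatter) toward a higher number. In this assay compound 4 is estimated at 1200 nM, within 500 nM to 3000 nM.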

Compound 4, concentration for 50% growth inhibition: 3180 nM
Compound 4: the middle estimate sits 2.7-fold (0.42 log units) below what was measured, and the stated range ends below it.
By their numbers in this assay, from the lowest: compound 3; then compounds 2, 1 and 4 (each within the scatter of the next, the first and the last beyond it).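

For the compounds shown here, compound 4 isolates the change that the earlier compounds could not: in this assay, with the rest of the structure held constant, placing 4-hydroxy-3-methoxyphenyl on the double-bonded chain carbon in place of 3,4,5-trimethoxyphenyl gives a clear loss of growth inhibition (a 7.2-fold higher number from compound 3 to compound 4 (0.86 log units; beyond the scatter)). With 4-hydroxy-3-methoxyphenyl fixed, changes on the aromatic carbon at the other site have less effect, as methoxy in place of hydrogen lies only just beyond the scatter (a 2.1-fold higher number from compound 2 to compound 4 (0.31 log units; beyond the scatter)) and methoxy in place of chloro stays within it (a 1.4-fold higher number from compound 1 to compound 4 (0.14 log units; within the scatter)). Among these four compounds, the enone aryl therefore gives the largest single-place step, while the hydrogen, chloro and methoxy variants that carry 4-hydroxy-3-methoxyphenyl all remain well above compound 3.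

Nothing available explains why this replacement costs so much. From the compounds shown here alone, the change removes a methoxy and introduces a hydroxy at once, so 3,4-dimethoxyphenyl or 4-hydroxy-3,5-dimethoxyphenyl would be needed to separate the two, and it remains open whether 3,4,5-trimethoxyphenyl gives a similar gain alongside the hydrogen of compound 2 or the chloro of compound 1.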